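A few compounds are considered here, and "the series" means these few. Any claim that something is new, unique, unknown or untested is made for them only; others in the source may bear on it.

Measured compounds:
compound 1 `C[C@@H]1CN(c2ccc(F)c(NS(=O)(=O)c3ccc(-c4ccccn4)s3)c2)C[C@H](C)N1` — 100 nM
compound 2 `COc1ccc(N2C[C@@H](C)N[C@@H](C)C2)cc1NS(=O)(=O)c1ccc(-c2cc(Cl)ccc2F)cc1` — 0.501 nM

Both were tested in a functional assay for agonist activity at growth hormone secretagogue receptor type 1 (Homo sapiens), read by FLIPR; a higher number here means that more compound is needed for the effect, a lower number that less compound is needed. Compound 2 has the lowest number of the two: its nearest neighbour, compound 1, sits at a far higher number, and this gap lies well beyond the usual scatter of repeated measurements. The two compounds differ in several places at once, so no single change can be read out of their values.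

Compound 3 `COc1ccc(N2C[C@@H](C)N[C@@H](C)C2)cc1NS(=O)(=O)c1ccc(-c2ccc(C)o2)cc1` is not yet measured. Among the measured compounds shown here, it keeps the core of compound 2 and changes only one group: 5-methylfuran-2-yl in place of 5-chloro-2-fluorophenyl on an aromatic carbon. For the measured compounds named here, no measured pair shows this exact change, so the direction can only be guessed from the size and make-up of what leaves and what enters. The expected step from compound 2 to compound 3 is a 6.0-fold higher number from compound 2 to compound 3 (0.78 log units; beyond the scatter), a modest loss. Compound 3 is therefore estimated at 3 nM, with a likely range from 0.5 nM to 20 nM.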

Compound 3, half-maximal effective concentration: 0.794 nM
For compound 3 the middle estimate is 3.8-fold (0.58 log units) above the measured one, and the stated range covers the measured number.
By their numbers in this assay, from the lowest: compounds 2 and 3 (each within the scatter of the next); then compound 1.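

In this assay, putting 5-methylfuran-2-yl in place of 5-chloro-2-fluorophenyl gives a 1.6-fold higher number from compound 2 to compound 3 (0.20 log units; within the scatter), so this assay does not tell the two compounds apart. At this place, on an aromatic carbon para to a large group, a five-membered aromatic ring with one hetero atom can therefore stand in for a six-membered ring of carbon only, even with fewer heavy atoms and no halogen. Nothing available here explains why the number holds across this change.

As far as these compounds go, it remains open whether the methyl on the furan or the chlorine and fluorine on the phenyl matter at all, as a plain furan-2-yl or phenyl would show. Also open, from the compounds shown here alone, is whether this place needs an aromatic ring, which a carboxylic acid or an amine there could test.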